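Methoxy for chloro on the aryl ring of compound 1

A few compounds are considered here, and "the series" means these few. Any claim that something is new, unique, unknown or untested is made for them only; others in the source may bear on it.

Compound 1 `COc1ccc(C(=O)/C(=C\c2ccc(Cl)cc2)Sc2ccc(F)cc2)cc1` carries a chloro group on the ring that hangs from the double bond. In a functional assay on DU-145 cells (Homo sapiens) for inhibition, read by trypan blue exclusion, with a stated time of 96 h (on this read-out lower numbers stand for stronger inhibition of growth and higher numbers for weaker inhibition of growth), compound 1 gives > 100000 nM, which is a limit of the assay rather than a number. Among the values shown, compound 1 sits at the limit of > 100000 nM in this assay, at which 1 of the 3 values shown sits. Among the measured compounds shown here, two other members, compound 2 `Cc1ccc(/C=C(\C(=O)c2ccc(Br)cc2)S(=O)(=O)Cc2ccc(F)cc2)s1` and compound 3 `O=C(O)c1ccc(C(=O)/C(=C\c2ccc(Cl)c([N+](=O)[O-])c2)SCc2ccc(F)cc2)cc1`, differ from compound 1 in several places at once, so no single step to either can be read off. In this assay compound 2 gives 1000 nM. In this assay compound 3 gives 1000 nM.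

Compound 4 `COc1ccc(/C=C(/Sc2ccc(F)cc2)C(=O)c2ccc(OC)cc2)cc1` differs from compound 1 in one place: methoxy in place of chloro on an aromatic carbon. For the measured compounds named here, no measured pair shows this change on its own, so its effect in this assay is unknown. Since compound 1 gives only a limit, a shift of the expected size from compound 1 to compound 4 would most likely still leave compound 4 near the edge of what the assay reports; the step of an at least 1.2-fold lower number from compound 1 to compound 4 (0.09 log units; that floor lies within the scatter) is expected to be modest and could fall within the scatter. Compound 4 is estimated at 80000 nM, with a range from 10000 nM to 300000 nM.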

Compound 4, concentration for 50% growth inhibition: 25000 nM
Compound 4: the middle estimate sits 3.2-fold (0.51 log units) above what was measured; the measured number falls inside the stated range.
By their numbers in this assay, from the lowest: compounds 2 and 3 (each within the scatter of the next); then compound 4. At a limit, above all of these: compound 1.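

In this assay, among the compounds shown here, methoxy in place of chloro on this aromatic carbon gives an at least 4.0-fold lower number from compound 1 to compound 4 (0.60 log units; beyond the scatter) and is the first change at this position that can be read as a single step. Going by these compounds, compound 1 gives > 100000 nM as a limit of the assay and not a number, so the step has only a floor and its full size stays unknown. The position is therefore not indifferent to what it carries, at least for 4-chlorophenyl to 4-methoxyphenyl with the rest of compound 1 unchanged, and compound 1 now stands alone at the limit: the limit of > 100000 nM in this assay, at which 1 of the 4 values shown sits.

One pair cannot separate what methoxy contributes from what the loss of chloro contributes, and it says nothing about whether the same change would hold on a different core. On these data alone, what an amine or an ethoxy group on this carbon would do to growth inhibition remains open, as does the effect of hydrogen at this place, which would show whether either substituent is needed at all.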